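A Hydroxy Group on the Azetidine Amide

This account rests on a few compounds, and the source may have more. Where it says the series, first, only, none or still open, it means among the compounds named here.

For the measured compounds named here, compound 3 `N#CC1(NC(=O)[C@@H]2C[C@@H](S(=O)(=O)c3ccccc3)C[C@H]2C(=O)N2CCC2)CC1` gives 10 nM in an assay on isolated protein for inhibition of cathepsin S (Homo sapiens), read by fluorescence, with a stated time of 20 min (a higher number here means a weaker inhibitor, a lower number a stronger inhibitor), the highest of the three numbers measured so far. In this assay compound 1 `C[C@@H]1CN(C(=O)[C@@H]2C[C@H](S(=O)(=O)c3ccccc3)C[C@H]2C(=O)NC2(C#N)CC2)C[C@H](C)O1` gives 0.4 nM and compound 2 `N#CC1(NC(=O)[C@@H]2C[C@@H](S(=O)(=O)c3ccccc3)C[C@H]2C(=O)N2CCC(O)CC2)CC1` gives 1 nM. The steps of a 25-fold higher number from compound 1 to compound 3 (1.40 log units; beyond the scatter) and a 10-fold higher number from compound 2 to compound 3 (1.00 log units; beyond the scatter) set compound 3 clearly apart from both, while the step of a 2.5-fold higher number from compound 1 to compound 2 (0.40 log units; beyond the scatter) is smaller.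

Compound 4 `N#CC1(NC(=O)[C@@H]2C[C@@H](S(=O)(=O)c3ccccc3)C[C@H]2C(=O)N2CC(O)C2)CC1` differs from compound 3 by hydroxy in place of hydrogen on a saturated ring carbon. Going by the values given here, no measured step isolates this change. The step of a 10-fold higher number from compound 2 to compound 3 (1.00 log units; beyond the scatter) comes closest, but there the ring size and the hydroxy group change together. How much of that step goes with the hydroxy group alone cannot be read from these data. The other steps replace the entire amide ring and say nothing direct about a hydroxy group on the four-membered ring.

The expected step is therefore a modest one toward a lower number, a 2.0-fold lower number from compound 3 to compound 4 (0.30 log units; within the scatter), with wide uncertainty. For compound 4 the estimated value in this assay is 5 nM, with an expected range from 1.5 nM to 15 nM.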

Compound 4, half-maximal inhibitory concentration: 7 nM
The estimate for compound 4 lay 1.4-fold (0.15 log units) below the measured number, and the stated range covers the measured number.
By their numbers in this assay, from the lowest: compound 1; then compound 2; then compounds 4 and 3 (each within the scatter of the next).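

In this assay, hydroxy in place of hydrogen on this saturated ring carbon gives a 1.4-fold lower number from compound 3 to compound 4 (0.15 log units; within the scatter), so this change alone leaves the number within the scatter. With a hydroxy group on both sides, the change of ring still gives a 7.0-fold higher number from compound 2 to compound 4 (0.85 log units; beyond the scatter), and replacing 2,6-dimethylmorpholin-4-yl with 3-hydroxyazetidin-1-yl gives an 18-fold higher number from compound 1 to compound 4 (1.24 log units; beyond the scatter), so the hydroxy group does not close the gap to either of these amides. No available evidence explains these results.

On these data alone, whether an amine, a carboxylic acid or a methoxy group on the same ring carbon would also stay within the scatter remains open. The compounds shown also leave open how far the unsubstituted piperidin-1-yl amide would lie from compound 2, which would isolate the hydroxy group on the six-membered ring.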